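Carboxylic acid amides on a shared core: a smaller acid

The source may report more compounds than this note shows. Statements on the series, on what has been measured and on what is new or still open speak of the compounds shown alone.

Measured compounds:
Compound 1 `C#CCNC(=O)c1ccc(C(CC)(CC)c2ccc(OCC(O)C(C)(C)C)c(C)c2)n1CC`: 240 nM
Compound 2 `CCn1c(C(=O)N(C)CCC#N)ccc1C(CC)(CC)c1ccc(OCC(O)C(C)(C)C)c(C)c1`: 1960 nM
Compound 3 `CC[C@@H](C)[C@H](NC(=O)c1ccc(C(CC)(CC)c2ccc(OCC(O)C(C)(C)C)c(C)c2)n1CC)C(=O)O`: 2.3 nM

In an assay on HL-60 cells for agonist activity at vitamin D3 receptor (Homo sapiens), read by microscopy, with a stated time of 96 h (on this read-out higher numbers stand for an effect only at larger amounts of compound and lower numbers for an effect already at smaller amounts), compound 3 gives the lowest number of the three, with compound 1 the nearest and compound 2 the furthest. Compound 4 `CCn1c(C(=O)N(C)CC(=O)O)ccc1C(CC)(CC)c1ccc(OCC(O)C(C)(C)C)c(C)c1` keeps the core of compound 3 and alters the amide: (carboxymethyl)(methyl)amino in place of (1-carboxy-2-methylbutyl)amino on a carbonyl carbon. For the measured compounds named here, two measured steps bear on this. The step of a 100-fold lower number from compound 1 to compound 3 (2.02 log units; beyond the scatter) shows how strongly the 1-carboxy-2-methylbutyl group lowers the number against propargyl; compound 4 keeps an acid but drops the 2-methylbutyl part and the amide hydrogen. The step of an 8.2-fold higher number from compound 1 to compound 2 (0.91 log units; beyond the scatter) shows that a (methyl)amino group carrying a non-acidic chain raised the number. Going by the values given here, compound 4 combines a retained acid with the methylated nitrogen, so a step upward is expected in this assay, smaller than the one from compound 1 to compound 3, giving a 17-fold higher number from compound 3 to compound 4 (1.24 log units; beyond the scatter). For compound 4 the value is estimated at 40 nM, in the range 8 nM to 200 nM.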

Compound 4, half-maximal effective concentration: 740 nM
For compound 4 the middle estimate is 19-fold (1.27 log units) below the measured one; measured number outside the range, above it.
By their numbers in this assay, from the lowest: compound 3; then compound 1; then compound 4; then compound 2.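

In this assay the change of amide gave a 320-fold higher number from compound 3 to compound 4 (2.51 log units; beyond the scatter), so a carboxylic acid on this carbonyl carbon does not by itself bring the low number of compound 3. With the methylated nitrogen kept, putting carboxy in place of cyanomethyl gave only a 2.6-fold lower number from compound 2 to compound 4 (0.42 log units; beyond the scatter), and the exchange against the propargylamino amide gave a 3.1-fold higher number from compound 1 to compound 4 (0.49 log units; beyond the scatter), both modest next to the first step. The low number of compound 3 therefore depends on more than the acid: on the 2-methylbutyl part, the amide hydrogen, or both together.

The compounds shown do not separate these, which a carboxymethylamino group or a (1-carboxy-2-methylbutyl)(methyl)amino group on the same carbonyl carbon could do. No measurement at hand explains the size of these steps.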